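4-Fluorophenyl in place of piperidin-4-yl in compound 2

The source may hold more compounds than are shown below. What is called first, only, known or untested is meant among the compounds shown, and "the series" means these compounds.

Within the data shown here, in a functional assay on DU-145 cells (Homo sapiens) for antiproliferative activity, read by MTT assay, with a stated time of 24 h (a lower number here means a stronger inhibitor, a higher number a weaker inhibitor), compound 2 (`COc1ccc(-c2noc(C3CCNCC3)n2)cc1OC1CCCC1`) gives 57 nM, the only actual number so far. Compound 1 (`COc1ccc(-c2noc(-c3ccncc3)n2)cc1OC1CCCC1`) reads > 1000000 nM, which is a limit of the assay. Compound 3 (`COc1ccc(-c2noc(-c3ccc(F)cc3)n2)cc1OC1CCCC1`) carries 4-fluorophenyl in place of piperidin-4-yl on an aromatic carbon. Among the measured compounds shown here, the one measured step bearing on this is large, an at least 17000-fold lower number from compound 1 to compound 2 (4.24 log units; beyond the scatter), and it is bounded by the limit of > 1000000 nM in this assay, at which 1 of the 2 values shown sits. It also involved leaving a six-membered aromatic ring, which compound 3 brings back, so a large step towards a higher number is expected in this assay. The expected step is a 1800-fold higher number from compound 2 to compound 3 (3.24 log units; beyond the scatter). For compound 3 the estimate is 100000 nM, with an expected range of 3000 nM to 1000000 nM.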

Compound 3, half-maximal inhibitory concentration: 20700 nM
The estimate for compound 3 lay 4.8-fold (0.68 log units) above the measured number; measured number inside the range.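

In this assay, among these compounds, 4-fluorophenyl on this aromatic carbon also falls far short of piperidin-4-yl, a 360-fold higher number from compound 2 to compound 3 (2.56 log units; beyond the scatter), so compound 1 is not the only compound with a six-membered aromatic ring here to do so. The two aromatic groups still differ, an at least 48-fold lower number from compound 1 to compound 3 (1.68 log units; beyond the scatter). Compound 1 gives a limit rather than a number, and this step is bounded by it: the limit of > 1000000 nM in this assay, at which 1 of the 3 values shown sits.

Open, as far as these compounds go, is whether the piperidine nitrogen or the non-aromatic ring carries the difference. Cyclohexyl or an open-chain amine at this carbon would separate the two.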